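A few compounds are considered here, and "the series" means these few. Any claim that something is new, unique, unknown or untested is made for them only; others in the source may bear on it.

Measured so far:
compound 1, `Nc1n[nH]c2cc(-c3ccncc3)[nH]c(=O)c12`: 29%
compound 2, `CC(=O)Nc1nn(C)c2cc(-c3ccccc3)[nH]c(=O)c12`: 3%
compound 3, `Cc1cc2nn(-c3ccccc3)c(N)c2c(=O)[nH]1`: 4%

In an assay on isolated protein for inhibition of ribosomal protein S6 kinase alpha-5 (Homo sapiens), read by mobility shift assay, tested at 30 uM (on this read-out lower numbers stand for less inhibition and higher numbers for more inhibition at the one concentration tested (going by the name of the read-out)), compound 1 gives 29%, compound 2 gives 3% and compound 3 gives 4%. Compound 3 therefore holds the second highest of the three numbers, but its nearest neighbour, compound 2, lies within the usual scatter of it, so no order between compound 2 and compound 3 can be claimed; only compound 1 stands clearly higher, beyond the scatter.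

Compound 4, `Nc1c2c(=O)[nH]c(-c3ccccn3)cc2nn1-c1ccccc1`, has not yet been measured. It differs from compound 3 by pyridin-2-yl in place of methyl on an aromatic carbon. Among the measured compounds shown here, no measured pair shows this change, so nothing can be read off directly; compound 1 gives 29%, yet it differs from compound 4 in several places and offers no step. In this assay a small upward step from compound 3 is expected, probably not beyond the scatter: a number 6 percentage points higher from compound 3 to compound 4 (within the scatter). Compound 4 is estimated at 10%, with a range from 0% to 30%.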

Compound 4, a percentage reported as inhibition, at one concentration (the size of the read-out at that concentration, not a potency): 4%
For compound 4 the middle estimate is 6 percentage points above the measured one, and the stated range covers the measured number.
By their numbers in this assay, from the lowest: compounds 2, 3 and 4 (each within the scatter of the next); then compound 1.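

Placing pyridin-2-yl instead of methyl on this aromatic carbon, next to the ring nitrogen, gives no change at the digits printed from compound 3 to compound 4 (within the scatter) in this assay. Among the compounds shown here, this is the first direct reading at this position, as the earlier compounds offered no pair differing in one place. Here, a six-membered aromatic ring with a hydrogen-bond acceptor and a single carbon read alike, and nothing available explains this result.

Still open, as far as these compounds go, is whether another group on this carbon, such as an amine, a carboxylic acid or a longer alkyl chain, would move the number, and whether pyridin-4-yl would read like pyridin-2-yl. From the compounds shown here alone, the same change also remains untested on a core with a higher starting number, such as the core of compound 1.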